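Swapping Butyl for Acetyl on the Amine Nitrogen

A few compounds are considered here, and "the series" means these few. Any claim that something is new, unique, unknown or untested is made for them only; others in the source may bear on it.

Measured so far:
- compound 1, `C#CCN(C)Cc1cn(-c2cc(NC(=S)NCC)ncn2)cn1`, gives 20.2% in an assay on isolated protein for inhibition of Amine oxidase [flavin-containing] A (Homo sapiens), read by fluorescence and Amplex Red, with a stated time of 15 min, tested at 50 uM; a lower number here means less inhibition, a higher number more inhibition at the concentration tested (going by the name of the read-out)
- compound 2, `C#CCN(CCCC)Cc1cn(-c2cc(NC(=S)NCC)ncn2)cn1`, gives 2.43% in this assay

Compound 2 holds the lower of the two numbers; its nearest neighbour is compound 1, whose number is higher by a gap beyond the scatter. Among the measured compounds shown here, the single measured step, a number 17.8 percentage points lower from compound 1 to compound 2 (beyond the scatter), belongs to putting propyl in place of hydrogen on a saturated chain carbon bound to an amine nitrogen, so a longer chain on that nitrogen went with weaker inhibition.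

Compound 3, `C#CCN(Cc1cn(-c2cc(NC(=S)NCC)ncn2)cn1)C(C)=O`, has not yet been tested. It differs from compound 2 by acetyl in place of butyl on an amine nitrogen. For the measured compounds named here, the one measured step bears on this only loosely: it speaks to chain length on the amine nitrogen, and acetyl is shorter than butyl, so a return upward toward compound 1 is possible; yet no measured pair shows an acetyl group here, so the size is uncertain. A modest rise in this assay is expected rather than none. Compound 3 is expected to give about 10%, within -5% to 30%. The expected step is a number 7.6 percentage points higher from compound 2 to compound 3 (within the scatter).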

Compound 3, a percentage reported as inhibition, at one concentration (the size of the read-out at that concentration, not a potency): 4.83%
Compound 3: the middle estimate sits 5.2 percentage points above what was measured; the range from low to high includes it.
By their numbers in this assay, from the lowest: compounds 2 and 3 (each within the scatter of the next); then compound 1.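

Putting acetyl in place of butyl on the amine nitrogen gives a number 2.4 percentage points higher from compound 2 to compound 3 (within the scatter) in this assay, so these two groups cannot be told apart here, even though acetyl brings a carbonyl and a hydrogen-bond acceptor that butyl lacks. Putting acetyl in place of methyl on the same nitrogen gives a number 15.4 percentage points lower from compound 1 to compound 3 (beyond the scatter), so compound 1 stands clear of both compound 2 and compound 3, and the earlier reading based on chain length alone no longer suffices: acetyl is shorter than butyl, yet it brings no measurable return toward compound 1. Nothing available explains why methyl differs from the other two groups or why those two fall together.

Going by these compounds, whether an ethyl or a propyl group on this nitrogen would fall with compound 1 or with compound 2 and compound 3 remains open, as does the effect of a plain hydrogen or a small ring such as cyclopropyl at the same place. All three numbers also come from a single concentration against one enzyme, so they give no potency and leave open how these changes would read at other concentrations.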